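Cyclopentyl on the Amide Nitrogen: What to Expect

The compounds below may be only part of what the source reports. "The series", "measured", "known", "first", "only" and "open" are said of these compounds alone.

Compound 1 `CCC1C(=O)N(C)c2cnc(-n3ccc4cc(C(N)=O)ccc43)nc2N1c1ccn(C)n1` gives 39500 nM in a functional assay on A549 cells (Homo sapiens) for antiproliferative activity, read by CCK-8 assay, with a stated time of 72 h; a lower number here means a stronger inhibitor of growth, a higher number a weaker inhibitor of growth.
Compound 2 `CC[C@@H]1C(=O)N(C)c2cnc(-n3ccc4cc(C(=O)NCC(C)C)ccc43)nc2N1C1CCCC1` gives 1730 nM in this assay.
Compound 3 `CC[C@@H]1C(=O)N(C)c2cnc(-n3ccc4cc(C(=O)NC)ccc43)nc2N1C1CCCC1` gives 2200 nM in this assay.

Among these three, compound 1 has the highest number, so it is the weakest inhibitor of growth in this assay; compound 3 and compound 2 both sit well below it, beyond the scatter. Compound 1 differs from compound 2 and compound 3 in more than one place, so those gaps cannot be assigned to a single change.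

Compound 4 `CCC1C(=O)N(C)c2cnc(-n3ccc4cc(C(=O)NC5CCCC5)ccc43)nc2N1c1ccn(C)n1` is compound 1 with one alteration: cyclopentyl in place of hydrogen on an amide-type nitrogen. Going by the values given here, the only measured step touching the amide side is a 1.3-fold higher number from compound 2 to compound 3 (0.10 log units; within the scatter), which shows that trading isopropyl for hydrogen on the chain attached to the amide-type nitrogen left the number essentially unchanged. That step is the closest guide, though it concerns a different group on a different atom, and it is from a series built on another core substituent. On this basis the cyclopentyl is expected to move the number by at most a small amount, most plausibly slightly downward, within the scatter: a 1.6-fold lower number from compound 1 to compound 4 (0.20 log units; within the scatter).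

Compound 4 is therefore estimated at 25000 nM in this assay, with a likely range from 8000 nM to 80000 nM.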

Compound 4, concentration for 50% growth inhibition: 39500 nM
Compound 4: middle estimate off by 1.6-fold (0.20 log units), on the low side, and the stated range covers the measured number.
By their numbers in this assay, from the lowest: compounds 2 and 3 (each within the scatter of the next); then compounds 1 and 4 (each within the scatter of the next).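

In this assay, going by these compounds alone, the step reads no change at the digits printed from compound 1 to compound 4 (within the scatter) and is the first measured change made directly on the amide-type nitrogen, since the step between compound 2 and compound 3 concerned a chain already attached to that nitrogen, on a different core. It shows that on the core of compound 1, the amide hydrogen can give way to cyclopentyl, a ring of 5 carbon atoms, without any readable effect on growth inhibition in this cell line. Nothing available here explains why the number stays put, so this result records only the outcome of the change and not its cause.

From the compounds shown here alone, what remains open is whether this indifference extends to other groups on the same nitrogen, such as a longer chain, a phenyl ring, or a chain ending in an amine or a carboxylic acid. It is also unknown whether replacing the amide hydrogen with cyclopentyl would leave the number equally unchanged on the core shared by compound 2 and compound 3, because a single pair on one core cannot establish a general rule.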